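A few compounds are considered here, and "the series" means these few. Any claim that something is new, unique, unknown or untested is made for them only; others in the source may bear on it.

Compound 1 `COc1ccc(-c2cnc(NC(=O)c3cccc(C#N)c3)n2C)cc1`: > 100000 nM
Compound 2 `COc1ccc(-c2cnc(NC(=O)c3ccn[nH]3)n2C)cc1`: > 100000 nM

Both entries come from a toxicity assay on THP-1 cells (Homo sapiens) for inhibition (a higher number here means that more compound is tolerated, a lower number that less compound is tolerated), and each is a limit of the assay rather than a number. Compound 2 is therefore known only by its limit of > 100000 nM.

Compound 3 `COc1ccc(-c2cnc(NC(=O)c3ccc(Cl)cc3)n2C)cc1` has not yet been measured. It keeps the core of compound 2 but changes the group on the carbonyl carbon: 4-chlorophenyl in place of 1H-pyrazol-5-yl on a carbonyl carbon. For the measured compounds named here, the only measured change at this place is a step that the two limits leave unreadable from compound 1 to compound 2, so it gives no size to carry over. What it does offer is the limit of > 100000 nM in this assay, at which 2 of the 2 values shown sit. Compound 1 also has a phenyl group at this place, and its limit is > 100000 nM. No change beyond the usual scatter is expected, and a number no higher from compound 2 to compound 3 (the limit leaves the size open) is the expected step. Another limit is the most likely report. The estimate for compound 3 is 100000 nM, with an expected range from 40000 nM to 200000 nM.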

Compound 3, half-maximal cytotoxic concentration: > 100000 nM
Compound 3 gave a limit, no number; the forecaster's own chance of this, stated with the estimate: 75%; the middle value lies on the limit itself.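

Compound 3, like compound 1 and compound 2, is reported only as a limit in this assay, so no step among the three can be read: the limit of > 100000 nM in this assay, at which 3 of the 3 values shown sit.

Left open is the concentration at which any of these compounds would harm the cells, and whether the group on the carbonyl carbon affects it.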